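Ethyl for Bromo on a Chromanone Enamine Sulfonamide

The source may report more compounds than this note shows. Statements on the series, on what has been measured and on what is new or still open speak of the compounds shown alone.

The measured compounds:
Compound 1 `CCOC1Oc2ccccc2C(=O)/C1=C\Nc1ccc(S(N)(=O)=O)cc1` gives 6800 nM in an assay on isolated protein for inhibition of alkaline phosphatase, tissue-nonspecific isozyme (Bos taurus), read by spectrophotometry, with stated times of 10 min and 30 min; a higher number here means a weaker inhibitor, a lower number a stronger inhibitor.
Compound 2 `CCOC1Oc2ccccc2C(=O)/C1=C\Nc1cccc(S(N)(=O)=O)c1` gives 41000 nM in this assay.
Compound 3 `CCOC1Oc2ccc(Br)cc2C(=O)/C1=C\Nc1cccc(S(N)(=O)=O)c1` gives 44000 nM in this assay.

Compound 3 holds the highest of the three numbers in this assay. Its nearest neighbour is compound 2, whose value lies within the scatter of that of compound 3, so no order between the two can be claimed; compound 1 stands furthest away, with a lower number beyond the scatter.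

Compound 4 `CCOC1Oc2ccc(CC)cc2C(=O)/C1=C\Nc1cccc(S(N)(=O)=O)c1` is not yet measured. It differs from compound 3 by ethyl in place of bromo on an aromatic carbon. For the measured compounds named here, the only measured step that bears on this position is the step from compound 2 to compound 3, where bromo replaced hydrogen: a 1.1-fold higher number from compound 2 to compound 3 (0.03 log units; within the scatter). Going by the values given here, no measured pair tells how ethyl compares with bromo at this place, so the data give no ground for expecting a step beyond the scatter in either direction in this assay.

Compound 4 is therefore estimated at 40000 nM, with a range of 13000 nM to 120000 nM, which means an expected step of a 1.1-fold lower number from compound 3 to compound 4 (0.04 log units; within the scatter).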

Compound 4, inhibition constant: 16800 nM
Beside the measured number, compound 4's estimate is 2.4-fold (0.38 log units) above it; measured number inside the range.
By their numbers in this assay, from the lowest: compound 1; then compound 4; then compounds 2 and 3 (each within the scatter of the next).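

In this assay this place on the aromatic ring had shown no step beyond the scatter, since bromo in place of hydrogen gave only a 1.1-fold higher number from compound 2 to compound 3 (0.03 log units; within the scatter). Ethyl now shows that the place does respond to what stands on it, with ethyl in place of bromo giving a 2.6-fold lower number from compound 3 to compound 4 (0.42 log units; beyond the scatter) and ethyl in place of hydrogen giving a 2.4-fold lower number from compound 2 to compound 4 (0.39 log units; beyond the scatter), so the two modest steps set ethyl apart from both hydrogen and bromo. Nothing available explains why ethyl differs from these two groups.

The compounds shown leave open whether a longer chain such as propyl, or an amine, at this place would carry the step further or reverse it. They also leave open whether ethyl would give a like step on compound 1.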